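Fluorophenyl to Chlorophenyl: Expected Effect on Cell Growth

This account rests on a few compounds, and the source may have more. Where it says the series, first, only, none or still open, it means among the compounds named here.

Compound 1 `Cc1nn(C)c(Oc2ccc(Cl)cc2)c1/C=N\CCCCCOc1cc2oc(=O)cc(C)c2cc1Cl`: 15300 nM
Compound 2 `Cc1nn(C)c(Oc2ccc(I)cc2)c1/C=N\CCCCCOc1cc2oc(=O)cc(C)c2cc1Cl`: > 25000 nM
Compound 3 `Cc1nn(C)c(Oc2cccc(F)c2)c1/C=N\CCCCCCOc1cc2oc(=O)cc(C)c2cc1Cl`: > 25000 nM

In a functional assay on HepG2 cells (Homo sapiens) for antiproliferative activity, read by MTT assay, with a stated time of 72 h (on this read-out lower numbers stand for stronger inhibition and higher numbers for weaker inhibition), compound 1 gives 15300 nM. Compound 2 reaches only a limit of the assay, > 25000 nM. Compound 3 likewise gives only a limit, > 25000 nM, so compound 3 stands at the limit of > 25000 nM in this assay, at which 2 of the 3 values shown sit, and no number is known for it. Within the data shown here, the one measured step, an at least 1.6-fold higher number from compound 1 to compound 2 (0.21 log units; that floor lies within the scatter), swaps one halogen for another on the same aromatic carbon and stays within the scatter at its floor. Compound 4 `Cc1nn(C)c(Oc2ccc(Cl)cc2)c1/C=N\CCCCCCOc1cc2oc(=O)cc(C)c2cc1Cl` differs from compound 3 by 4-chlorophenyl in place of 3-fluorophenyl on an oxygen on an aromatic ring. Among the measured compounds shown here, that step has no direct measured counterpart. Compound 4 is therefore expected to remain weak, with an at least 1.1-fold lower number from compound 3 to compound 4 (0.05 log units; that floor lies within the scatter) and an estimated value of 22000 nM (range 9000 nM to 60000 nM).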

Compound 4, half-maximal inhibitory concentration: 2960 nM
Compound 4: the middle estimate sits 7.4-fold (0.87 log units) above what was measured; the whole stated range lies above it.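

Replacing 3-fluorophenoxy with 4-chlorophenoxy gives an at least 8.4-fold lower number from compound 3 to compound 4 (0.92 log units; beyond the scatter) in this assay. This step lies beyond the scatter, so the group on this oxygen can matter for antiproliferative activity on the hexyl-free reading of the shared core alone. Its true size stays open because compound 3 stands at a limit and not at a number: the limit of > 25000 nM in this assay, at which 2 of the 4 values shown sit.

The halogen and its place on the ring change together in this step, and the compounds shown do not separate the two. They also leave open how a methoxy group or an amine on that ring would fare.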